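One Methyl Removed: What to Expect for Compound 4

The compounds below may be only part of what the source reports. "The series", "measured", "known", "first", "only" and "open" are said of these compounds alone.

Of the compounds shown here, three have been measured so far in a functional assay on OVCAR-5 cells (Homo sapiens) for inhibition, read by sulforhodamine B assay, with a stated time of 48 h; on this read-out higher numbers stand for weaker inhibition of growth and lower numbers for stronger inhibition of growth. Compound 1 `COc1cc(-c2nn(-c3cccc(NC(=O)Nc4cc(C(F)(F)F)cc(C(F)(F)F)c4)c3)cc2-c2ccncc2)ccc1Cl` gives 2470 nM. Compound 2 `O=C(Nc1cccc(-n2cc(-c3ccncc3)c(-c3ccc(Cl)c(O)c3)n2)c1)Nc1cc(C(F)(F)F)cc(C(F)(F)F)c1` gives 2030 nM. Compound 3 `COc1cc(-c2nn(-c3cccc(NC(=O)Nc4ccc(Cl)c(C(F)(F)F)c4)c3)cc2-c2ccncc2)ccc1Cl` gives 11000 nM, the highest of the three numbers, and its gaps to compound 1 and to compound 2 both lie beyond the usual scatter of this kind of measurement.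

Compound 2 differs from compound 1 in one place: hydrogen in place of methyl on an oxygen on an aromatic ring. The size of that step is a 1.2-fold lower number from compound 1 to compound 2 (0.09 log units; within the scatter). Compound 3 and compound 1 differ in more than one place, and the difference between the two cores is not broken down here.

Compound 4 `O=C(Nc1cccc(-n2cc(-c3ccncc3)c(-c3ccc(Cl)c(O)c3)n2)c1)Nc1ccc(Cl)c(C(F)(F)F)c1` has not yet been measured. It differs from compound 3 in one place: hydrogen in place of methyl on an oxygen on an aromatic ring. Among the compounds with values here, this is the same change, made at the same kind of place, as the one that turns compound 1 into compound 2.

Within the data shown here, only that one earlier example of the change is available, and it barely moved the number. The step from compound 3 to compound 4 in this assay is therefore expected to be a 1.2-fold lower number from compound 3 to compound 4 (0.09 log units; within the scatter). This expectation rests on compound 1 and compound 2, because the same change there gave a 1.2-fold lower number from compound 1 to compound 2 (0.09 log units; within the scatter). The estimated value for compound 4 is 9000 nM. Its expected lower end is 4000 nM and its expected upper end is 20000 nM, the width reflecting that one example is a thin basis.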

Compound 4, concentration for total growth inhibition: 16200 nM
Compound 4: the middle estimate sits 1.8-fold (0.26 log units) below what was measured, within the range that was stated.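

On the core of compound 3, replacing methoxy with hydroxy in this assay gives a 1.5-fold higher number from compound 3 to compound 4 (0.17 log units; within the scatter), so the measured step is no larger than the ordinary spread between repeat measurements. Set beside the same replacement on the core of compound 1, the new step agrees with the earlier one, and neither stands out from the scatter: the same change on two cores in this assay, a 1.2-fold lower number (0.09 log units; within the scatter) from compound 1 to compound 2 and a 1.5-fold higher number (0.17 log units; within the scatter) from compound 3 to compound 4, 1.8-fold (0.25 log units) apart, within the scatter of two such steps Across these two cores, then, the swap from 4-chloro-3-methoxyphenyl to 4-chloro-3-hydroxyphenyl carries over in the sense that it leaves the number within the scatter both times, but two pairs do not make a rule for other cores, steps this small cannot separate a slight real shift from none at all, and the result says nothing about why the number behaves this way or how the swap would read in any other test.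

The compounds shown leave open whether a different group at this place, such as an amine or a carboxylic acid in place of the hydroxy, or a longer chain on the oxygen, would move the number beyond the scatter. They also leave open whether the methoxy-to-hydroxy swap would stay this quiet on a third core.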